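A Methyl Added to an Aromatic Ring of Compound 3

The source may report more compounds than this note shows. Statements on the series, on what has been measured and on what is new or still open speak of the compounds shown alone.

In a functional assay on HeLa cells (Homo sapiens) for cytotoxicity, read by sulforhodamine B assay (on this read-out lower numbers stand for stronger inhibition and higher numbers for weaker inhibition), compound 3 `COc1ccc(Cn2c(-c3ccccc3O)c(Br)c3ccccc3c2=O)cc1` gives 36800 nM. Among the three compounds measured so far this is the second highest number. Compound 1 `COc1cc2c3c(n(C)c(=O)c2cc1OC)-c1ccccc1OCC3` gives 38100 nM, which lies within the scatter of compound 3 and cannot be told apart from it. Compound 2 `COc1ccc(Cn2c3c(c4cc(C)ccc4c2=O)CCOc2ccccc2-3)cc1` gives 10300 nM, a lower number beyond the scatter, which means stronger inhibition. Compound 4 `COc1ccc(Cn2c(-c3ccccc3O)c(Br)c3cc(C)ccc3c2=O)cc1` has not yet been measured. It differs from compound 3 by methyl in place of hydrogen on an aromatic carbon. Among the measured compounds shown here, no two measured compounds differ in just one place, so there is no comparable step to lean on. The methyl is expected to change the number only a little, with a step in this assay of a 1.5-fold lower number from compound 3 to compound 4 (0.17 log units; within the scatter) that may stay within the scatter. Compound 4 is therefore expected to give about 25000 nM, within a range from 8000 nM to 80000 nM.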

Compound 4, half-maximal inhibitory concentration: 20400 nM
For compound 4 the middle estimate is 1.2-fold (0.09 log units) above the measured one; measured number inside the range.
By their numbers in this assay, from the lowest: compounds 2, 4, 3 and 1 (each within the scatter of the next, the first and the last beyond it).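

In this assay, among the compounds shown here, the exchange of hydrogen for methyl on this aromatic carbon gives a 1.8-fold lower number from compound 3 to compound 4 (0.26 log units; within the scatter) and is the first comparison of two compounds that differ in one place. This step lies within the scatter, so compound 3 and compound 4 cannot be told apart, and methyl at this position shows no clear effect on the number. Nothing shown here explains the step.

On these data alone, whether a methoxy group, an amine or a carboxylic acid on this same carbon would give a step beyond the scatter remains open.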